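Swapping the anilino aryl group in a pyrimidine urea series

This account rests on a few compounds, and the source may have more. Where it says the series, first, only, none or still open, it means among the compounds named here.

Measured so far:
compound 1, `COc1cc(NC(=O)Nc2cc(Nc3ccc(F)c(Cl)c3)ncn2)cc(OC)c1`: 36.7%
compound 2, `COc1ccc(Br)cc1Nc1cc(NC(=O)Nc2c(Cl)cccc2Cl)ncn1`: 33%
compound 3, `COc1ccc(Nc2cc(NC(=O)Nc3c(Cl)cccc3Cl)ncn2)cc1C`: 50%

Of the compounds shown here, three sharing one core have been tested in a functional assay on NCI-H226 cells (Homo sapiens) for inhibition, read by MTT assay, with a stated time of 48 h, tested at 10 uM; a higher number here means more inhibition at the concentration tested (going by the name of the read-out), a lower number less inhibition. Compound 1 stands second highest of the three; compound 2 lies within the scatter of it, while compound 3 sits beyond the scatter above it. Within the data shown here, the only single-site step available, a number 17 percentage points higher from compound 2 to compound 3 (beyond the scatter), changes the aryl group on the amine nitrogen and is modest in size.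

The unmeasured compound 4, `COc1cc(NC(=O)Nc2cc(Nc3ccc(OC)c(I)c3)ncn2)cc(OC)c1`, differs from compound 1 at that same nitrogen: 3-iodo-4-methoxyphenyl in place of 3-chloro-4-fluorophenyl on a nitrogen on an aromatic ring. The measured step bears on this change because a number 17 percentage points higher from compound 2 to compound 3 (beyond the scatter) also swaps the aryl on that nitrogen, and the entering group there, like the one entering here, carries a methoxy. A step of similar, modest size upward is therefore expected, although a single precedent is a thin basis. The expected step is a number 9.3 percentage points higher from compound 1 to compound 4 (within the scatter). Compound 4 is estimated at 46%, with a range from 26% to 66%.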

Compound 4, a percentage reported as inhibition, at one concentration (the size of the read-out at that concentration, not a potency): 40.1%
Compound 4: middle estimate off by 5.9 percentage points, on the high side; the measured number falls inside the stated range.
By their numbers in this assay, from the lowest: compounds 2, 1, 4 and 3 (each within the scatter of the next, the first and the last beyond it).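

In this assay, the change from 3-chloro-4-fluorophenyl to 3-iodo-4-methoxyphenyl on a nitrogen on an aromatic ring gives a number 3.4 percentage points higher from compound 1 to compound 4 (within the scatter), so on the core of compound 1 this exchange of aryl groups produces no difference that can be told from the scatter. The earlier step at this nitrogen, a number 17 percentage points higher from compound 2 to compound 3 (beyond the scatter), also brought in an aryl group carrying a methoxy, and the new step shows that such an entering group does not always go with a difference beyond the scatter. Nothing available accounts for this result, and no part of it can be assigned to the iodine, the methoxy, the chlorine or the fluorine.

The compounds shown leave open how this nitrogen would respond to an aryl group bearing an amine or a carboxylic acid. They also leave open whether 3-iodo-4-methoxyphenyl would give a similar number on the core of compound 3.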